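The compounds below may be only part of what the source reports. "The series", "measured", "known", "first", "only" and "open" are said of these compounds alone.

Measured compounds:
Compound 1, `N#Cc1ncccc1S(=O)(=O)N1CCN(c2ccc(C(=O)NCc3ccc(F)cc3)nn2)CC1`, in an ADME assay on microsomes from liver (Mus musculus) for metabolic stability, read by LC-MS, using NADPH, tested at 10 uM (a lower number here means that the compound disappears faster, a higher number that the compound lasts longer), gives 0.0833 h.
Compound 2, `Cc1ccccc1S(=O)(=O)N1CCN(c2ccc(C(=O)NCc3ccc(F)cc3)nn2)CC1`, gives 0.433 h.
Compound 3, `Cc1ncccc1S(=O)(=O)N1CCN(c2ccc(C(=O)NCc3ccc(F)cc3)nn2)CC1`, gives 0.133 h.

Compound 3 stands second highest of the three numbers. Its nearest neighbour is compound 1, and that gap lies within the scatter (a 1.6-fold higher number from compound 1 to compound 3 (0.20 log units; within the scatter)). Going by the values given here, the only step beyond the scatter that reaches compound 3 is the one from compound 2 (a 3.3-fold lower number from compound 2 to compound 3 (0.51 log units; beyond the scatter)), and compound 2 also stands apart from compound 1 (a 5.2-fold higher number from compound 1 to compound 2 (0.72 log units; beyond the scatter)).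

Compound 4, `Nc1ncccc1S(=O)(=O)N1CCN(c2ccc(C(=O)NCc3ccc(F)cc3)nn2)CC1`, has not yet been measured. It differs from compound 3 as follows: amino in place of methyl on an aromatic carbon.

Of the measured steps, the one that bears most directly on this change is the swap of a small group on the same aromatic carbon, from compound 1 to compound 3 (a 1.6-fold higher number from compound 1 to compound 3 (0.20 log units; within the scatter)), which stayed within the scatter. The larger steps each involved exchanging the whole ring, which is not what happens here. Compound 4 is therefore expected to give a number close to that of compound 3, with no step beyond the scatter (a 1.0-fold lower number from compound 3 to compound 4 (0.01 log units; within the scatter)). The estimate for compound 4 is 0.13 h, with a range from 0.055 h to 0.3 h.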

Compound 4, half-life: 0.317 h
Estimate against measurement, compound 4: 2.4-fold (0.39 log units) below, outside the stated range (above it).
By their numbers in this assay, from the lowest: compounds 1 and 3 (each within the scatter of the next); then compounds 4 and 2 (each within the scatter of the next).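

In this assay, putting amino in place of methyl on the aromatic carbon next to the ring nitrogen moves the number beyond the scatter (a 2.4-fold higher number from compound 3 to compound 4 (0.38 log units; beyond the scatter)), so this position can respond to the exchange of one small group, which the change from cyano to methyl on the same carbon had not shown. Amino also stands apart from cyano at this carbon (a 3.8-fold higher number from compound 1 to compound 4 (0.58 log units; beyond the scatter)), while the compound with 2-aminopyridin-3-yl on the sulfonyl sulfur stays within the scatter of the one with 2-methylphenyl (a 1.4-fold lower number from compound 2 to compound 4 (0.14 log units; within the scatter)). Nothing presented here accounts for the shift seen with amino.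

On these data alone, it remains open whether other groups on this carbon, such as a hydroxyl, a methoxy or a dimethylamino group, would behave like amino or like methyl. As far as these compounds go, it is also open whether amino would have a similar effect on the ring without its nitrogen, as in 2-aminophenyl on the sulfonyl sulfur.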